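Side chain on sulfur: from phenethyl to ethynyl

The compounds below may be only part of what the source reports. "The series", "measured", "known", "first", "only" and "open" are said of these compounds alone.

In a functional assay on MCF7 cells (Homo sapiens) for inhibition, read by MTT assay, with a stated time of 72 h (a higher number here means a weaker inhibitor, a lower number a stronger inhibitor), compound 1 `Cc1cc(Nc2cc(-c3ccccc3)[nH]n2)n2nc(SCc3c(Cl)cccc3Cl)nc2n1` gives 3230 nM, compound 2 `Cc1cc(Nc2cc(-c3ccccc3)[nH]n2)n2nc(SCc3ccc(Br)cc3)nc2n1` gives 2720 nM and compound 3 `Cc1cc(Nc2cc(-c3ccccc3)[nH]n2)n2nc(SCCCc3ccccc3)nc2n1` gives 3900 nM. Compound 3 therefore stands level with the other two: a 1.2-fold higher number from compound 1 to compound 3 (0.08 log units; within the scatter) and a 1.4-fold higher number from compound 2 to compound 3 (0.16 log units; within the scatter) both lie within the scatter, as does a 1.2-fold lower number from compound 1 to compound 2 (0.07 log units; within the scatter). Compound 4 `C#CCSc1nc2nc(C)cc(Nc3cc(-c4ccccc4)[nH]n3)n2n1` follows from compound 3 by ethynyl in place of phenethyl on a saturated chain carbon bound to a sulfur, in words ethynyl in place of phenethyl on a saturated chain carbon bound to a sulfur. Every measured compound keeps a six-membered aromatic ring of carbon only, so these flat steps bear only loosely on its loss. In this assay, the expected step is a 1.2-fold higher number from compound 3 to compound 4 (0.06 log units; within the scatter), slightly toward a higher number and not beyond the scatter. For compound 4 the estimate is 4500 nM, with an expected range of 1800 nM to 12000 nM.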

Compound 4, half-maximal inhibitory concentration: 21800 nM
For compound 4 the middle estimate is 4.8-fold (0.69 log units) below the measured one; the measured number lies above the stated range.
By their numbers in this assay, from the lowest: compounds 2, 1 and 3 (each within the scatter of the next); then compound 4.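

In this assay this position is not indifferent: the side chains on sulfur that carry a six-membered aromatic ring of carbon only stood level, but ethynyl in their place gives a 5.6-fold higher number from compound 3 to compound 4 (0.75 log units; beyond the scatter) and an 8.0-fold higher number from compound 2 to compound 4 (0.90 log units; beyond the scatter) and a 6.7-fold higher number from compound 1 to compound 4 (0.83 log units; beyond the scatter). All three steps lie beyond the scatter and point the same way, so the position tolerates changes among those ring-bearing chains but not this replacement. Nothing available accounts for this loss. As far as these compounds go, whether a hexyl chain on the sulfur would stay level with compound 3 or fall toward compound 4 remains open, so the loss of the ring cannot be separated from the shortening of the chain. From the compounds shown here alone, an amine at the end of the chain is equally open.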